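Amide variation in a cell inhibition series: fluoro for methoxy

This account rests on a few compounds, and the source may have more. Where it says the series, first, only, none or still open, it means among the compounds named here.

Measured compounds:
compound 1 `COc1ccc2c(=O)c(/C=C/C(=O)Nc3cccc(C)c3)coc2c1`: > 200000 nM
compound 2 `COc1ccc2c(=O)c(/C=C/C(=O)NCc3ccccc3F)coc2c1`: > 200000 nM
compound 3 `COc1ccc(NC(=O)/C=C/c2coc3cc(OC)ccc3c2=O)cc1`: > 200000 nM

In a functional assay on L02 cells (Homo sapiens) for inhibition, read by MTT assay, with a stated time of 48 h (on this read-out higher numbers stand for weaker inhibition and lower numbers for stronger inhibition), compound 3 gives only a limit, not a number; it sits at the limit of > 200000 nM in this assay, at which 3 of the 3 values shown sit, where all values shown in this assay sit. Compound 1 gives a limit as well. Compound 2 gives a limit as well. The measured steps are therefore unreadable in size: a step that the two limits leave unreadable from compound 1 to compound 2, a step that the two limits leave unreadable from compound 1 to compound 3 and a step that the two limits leave unreadable from compound 2 to compound 3 show no more than that changing the group on the amide-type nitrogen among 3-methylphenyl, 2-fluorobenzyl and 4-methoxyphenyl leaves every compound at the same limit.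

Compound 4 `COc1ccc2c(=O)c(/C=C/C(=O)Nc3ccc(F)cc3)coc2c1` is not yet measured. It differs from compound 3 by fluoro in place of methoxy on an aromatic carbon. No measured step bears on this change in a readable way; the three steps shown only say that three different groups on the amide-type nitrogen all stay at the limit.

Compound 4 is therefore expected to stay at that limit too, with a step that the limit leaves unreadable from compound 3 to compound 4 as the expected step. The estimate for compound 4 in this assay is 250000 nM, expected between 100000 nM and 1000000 nM, most likely reported again as a limit rather than a number.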

Compound 4, half-maximal inhibitory concentration: > 200000 nM
Compound 4 was reported as a limit; the forecaster's own chance of this, stated with the estimate: 80%; the middle value lies beyond the limit too.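

In this assay compound 4 gives > 200000 nM, a limit and not a number. No step linking compound 4 to compound 1, compound 2 or compound 3 can be read, because all four compounds sit at the same limit: the limit of > 200000 nM in this assay, at which 4 of the 4 values shown sit.

The compounds shown leave open whether the groups on the amide-type nitrogen differ at all in this inhibition, and at what concentration any of these compounds would reach half-maximal inhibition.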